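A few compounds are considered here, and "the series" means these few. Any claim that something is new, unique, unknown or untested is made for them only; others in the source may bear on it.

Measured so far in a functional assay on MCF7 cells (Homo sapiens) for inhibition, read by sulforhodamine B assay, with a stated time of 72 h; on this read-out lower numbers stand for stronger inhibition of growth and higher numbers for weaker inhibition of growth:
- compound 1 `CCOC(=O)/C=C/c1ccncc1-c1ccc2cc[nH]c2c1`: 6880 nM
- compound 2 `COC1CN(C(=O)/C=C/c2ccncc2-c2ccc3ccccc3c2)C1`: > 10000 nM

For the measured compounds named here, compound 1 holds the only actual number in this assay. The entry for compound 2, > 10000 nM, is a limit of the assay and not a number.

Compound 3 `O=C(O)/C=C/c1ccncc1-c1ccc2cc[nH]c2c1` follows from compound 1 by hydrogen in place of ethyl on an oxygen next to a carbonyl group, ethoxycarbonyl to carboxy. Going by the values given here, no measured pair covers this change, so the direction is a judgement: a moderate move towards weaker inhibition of growth in this assay is expected. The expected size is a 1.7-fold higher number from compound 1 to compound 3 (0.24 log units; within the scatter). Compound 3 is estimated at 12000 nM, within an expected range of 5000 nM to 35000 nM.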

Compound 3, concentration for 50% growth inhibition: > 10000 nM
Compound 3: only a limit was reported; the forecaster's own chance of this, stated with the estimate: 50%; the middle value lies beyond the limit too.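

In this assay compound 3 gives > 10000 nM, which is a limit of the assay and not a number. Hydrogen in place of ethyl on an oxygen next to a carbonyl group gives an at least 1.4-fold higher number from compound 1 to compound 3 (0.16 log units; that floor lies within the scatter), so this floor does not show whether the ethyl matters at this position. Compound 3 adds a further entry at the limit, and the true size of the step stays unread: the limit of > 10000 nM in this assay, at which 2 of the 3 values shown sit.

Open, from the compounds shown here alone, is whether a longer chain than ethyl on this oxygen, or a primary amide in place of the ester, gives an actual number in this assay.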